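The compounds below may be only part of what the source reports. "The series", "measured", "known", "first", "only" and "open" are said of these compounds alone.

Compound 3 `CC(C)(C)N(NC(=O)c1ccccc1I)C(=O)c1ccccc1Cl` gives 1290 nM in an assay on cells for agonist activity at ecdysone receptor (Bombyx mori), read by a luciferase reporter, with a stated time of 24 h (a lower number here means that less compound is needed, a higher number that more compound is needed for the effect), and holds the highest number of the three measured; compound 2 `CCc1ccccc1C(=O)N(NC(=O)c1ccccc1)C(C)(C)C` gives 589 nM, and compound 1 `CC(C)(C)N(NC(=O)c1ccccc1)C(=O)c1ccccc1Br` gives 170 nM. Among the compounds with values here, the one single-point step is a 3.5-fold higher number from compound 1 to compound 2 (0.54 log units; beyond the scatter). Compound 4 `CC(C)(C)N(NC(=O)c1ccc(F)cc1)C(=O)c1ccccc1Cl` takes the change (4-fluorophenyl in place of 2-iodophenyl on a carbonyl carbon). Within the data shown here, no measured step matches this change: the step from compound 1 to compound 2 sits on the other aromatic ring, and no pair differs only in the ring on this carbonyl. What the values show is that compound 1, which carries an unsubstituted phenyl on this carbonyl, sits well under compound 3, which carries 2-iodophenyl there. A move downward from compound 3 is therefore expected, of moderate size, with the direction uncertain. For compound 4 the expected value in this assay is 450 nM, with a range of 150 nM to 1400 nM. This estimate means an expected step of a 2.9-fold lower number from compound 3 to compound 4 (0.46 log units; beyond the scatter).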

Compound 4, half-maximal effective concentration: 389 nM
Compound 4: middle estimate off by 1.2-fold (0.06 log units), on the high side; the range from low to high includes it.
By their numbers in this assay, from the lowest: compound 1; then compounds 4 and 2 (each within the scatter of the next); then compound 3.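

In this assay, within the data shown here, 4-fluorophenyl in place of 2-iodophenyl on a carbonyl carbon gives a 3.3-fold lower number from compound 3 to compound 4 (0.52 log units; beyond the scatter) and is the first direct reading at this position, since the earlier step sat on the other aromatic ring. The number at this carbonyl therefore responds to the aryl group it carries, with the rest of the molecule held constant. The change alters both the halogen and its place on the ring, so this single step cannot assign the shift to either one, and no supporting measurement bears on it.

Still open, on these data alone, is whether the halogen or its ring position drives the step, which 4-iodophenyl and 2-fluorophenyl at this carbonyl would separate. Also open, as far as these compounds go, is how a non-halogen group, such as 4-methoxyphenyl or 4-aminophenyl, would read here.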